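Replacing vinylsulfonyl with fluoro: expected half-life in buffer

A few compounds are considered here, and "the series" means these few. Any claim that something is new, unique, unknown or untested is made for them only; others in the source may bear on it.

Compound 1 `C=CC(=O)Oc1cc(C(F)(F)F)cc(C(F)(F)F)c1`: in an ADME assay for pharmacokinetics, read by LC-MS, in phosphate buffer, with a stated time of 72 h, at pH 7.4, tested at 250 uM (a higher number here means that the compound lasts longer, a lower number that the compound disappears faster), compound 1 gives < 0.017 h, which is a limit of the assay rather than a number.
Compound 2 `C=CS(=O)(=O)c1cc(C(F)(F)F)cc(C(F)(F)F)c1`: in this assay compound 2 gives < 0.017 h, also a limit.
Compound 3 `FC(F)(F)c1cc(C2CO2)cc(C(F)(F)F)c1`: in this assay compound 3 gives > 50 h, again a limit.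

Within the data shown here, compound 2 therefore stands at the short end of what this assay can report, a position shared by the limit of < 0.017 h in this assay, at which 2 of the 3 values shown sit; the only value at the long end is the limit of > 50 h in this assay, at which 1 of the 3 values shown sits. Compound 4 `Fc1cc(C(F)(F)F)cc(C(F)(F)F)c1` differs from compound 2 by fluoro in place of vinylsulfonyl on an aromatic carbon. Among the measured compounds shown here, the one measured step that starts from compound 2 is an at least 2900-fold higher number from compound 2 to compound 3 (3.46 log units; beyond the scatter), and the parallel step an at least 2900-fold higher number from compound 1 to compound 3 (3.46 log units; beyond the scatter) is of the same size; the step that the two limits leave unreadable from compound 1 to compound 2 cannot be sized because both of its values are limits. Both readable steps take the half-life from the lower limit to the upper one when the vinylsulfonyl or (vinylcarbonyl)oxy group is removed. The step of an at least 5800-fold higher number from compound 2 to compound 4 (3.76 log units; beyond the scatter) is therefore expected to be similarly large. Compound 4 is estimated at 100 h, within a range from 30 h to 1000 h, and will most likely be reported only as the upper limit.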

Compound 4, half-life: > 50 h
Compound 4 was reported as a limit; the forecaster's own chance of this, stated with the estimate: 85%; the middle value lies beyond the limit too.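

Swapping vinylsulfonyl for a single fluoro gives an at least 2900-fold higher number from compound 2 to compound 4 (3.46 log units; beyond the scatter), and the same swap for (vinylcarbonyl)oxy gives an at least 2900-fold higher number from compound 1 to compound 4 (3.46 log units; beyond the scatter). A second replacement at this place, much smaller than oxiran-2-yl, therefore also reaches the long end of this assay, so the shared core with its two trifluoromethyl groups does not by itself bring the very short half-life seen for compound 1 and compound 2. The step from compound 3 to compound 4 cannot be read, since both values are limits, and the long end now holds as many compounds as the short end: the limit of > 50 h in this assay, at which 2 of the 4 values shown sit.

How long compound 3 and compound 4 actually last, and whether they differ, stays hidden behind those limits. Also open, going by these compounds, is where an amine or a carboxylic acid at this place would fall in this range.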